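Swapping trifluoromethyl for isopropyl on a potent compound

This account rests on a few compounds, and the source may have more. Where it says the series, first, only, none or still open, it means among the compounds named here.

Compounds measured in a functional assay on the whole organism for inhibition, with Rattus norvegicus as the target; on this read-out lower numbers stand for an effect already at smaller amounts and higher numbers for an effect only at larger amounts of compound
Compound 1 `CC(C)c1ccc(OC(Cc2ccc(C(F)(F)F)cc2)C(=O)O)cc1` gives 10 mg/kg
Compound 2 `CC(C)c1ccc(OC(C)(Cc2ccc(C(F)(F)F)cc2)C(=O)O)cc1` gives < 5 mg/kg

The entry for compound 2, < 5 mg/kg, is a limit of the assay and not a number. Compound 3 `CC(C)c1ccc(CC(C)(Oc2ccc(C(C)C)cc2)C(=O)O)cc1` has isopropyl in place of trifluoromethyl on an aromatic carbon, para to a large group (isopropyl in place of trifluoromethyl on an aromatic carbon). Among the measured compounds shown here, the only measured step, an at least 2.0-fold lower number from compound 1 to compound 2 (0.30 log units; that floor lies within the scatter), puts methyl in place of hydrogen on a saturated chain carbon, so it gives no size for this swap. No change beyond the usual scatter is therefore expected in this assay. The expected step is a step that the limit leaves unreadable from compound 2 to compound 3. For compound 3 the estimated value is 4 mg/kg, with an expected range from 1.5 mg/kg to 12 mg/kg.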

Compound 3, dose for half-maximal effect: 5 mg/kg
Compound 3: the middle estimate sits 1.3-fold (0.10 log units) below what was measured; the measured number falls inside the stated range.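

In this assay compound 3 gives 5 mg/kg, so with isopropyl on this aromatic carbon the effect can still be stated as a plain number. Compound 2 gives < 5 mg/kg, which is a limit and not a number. The change from trifluoromethyl to isopropyl gives a number no lower from compound 2 to compound 3 (the limit leaves the size open), and its size therefore cannot be read: the limit of < 5 mg/kg in this assay, at which 1 of the 3 values shown sits.

Going by these compounds, it remains open how the dose in this assay would respond to a chlorine atom or a methoxy group on this same aromatic carbon.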